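Amide to urea on a shared core: expected cell potency

The source may hold more compounds than are shown below. What is called first, only, known or untested is meant among the compounds shown, and "the series" means these compounds.

Compound 1 `CN(C(=O)c1ccc(F)cc1)c1ccc2[nH]c(-c3n[nH]c4ccccc34)cc2n1`: 1210 nM
Compound 2 `CN(c1ccc2[nH]c(-c3n[nH]c4ccccc34)cc2n1)S(=O)(=O)c1ccccc1`: 3700 nM
Compound 3 `Cc1ccc(S(=O)(=O)N(C)c2ccc3[nH]c(-c4n[nH]c5ccccc45)cc3n2)cc1`: 3030 nM

All three were tested in a functional assay on HL-60 cells (Homo sapiens) for antiproliferative activity, read by MTT assay, with a stated time of 72 h; on this read-out lower numbers stand for stronger inhibition and higher numbers for weaker inhibition. Compound 1 gives the lowest number of the three: a 3.1-fold higher number from compound 1 to compound 2 (0.49 log units; beyond the scatter) and a 2.5-fold higher number from compound 1 to compound 3 (0.40 log units; beyond the scatter), both beyond the scatter, so compound 1 is the most potent of the measured set. The two sulfonyl compounds sit close together, a 1.2-fold lower number from compound 2 to compound 3 (0.09 log units; within the scatter), within the scatter.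

Compound 4 `COc1ccc(NC(=O)N(C)c2ccc3[nH]c(-c4n[nH]c5ccccc45)cc3n2)cc1` has not been measured. It keeps the carbonyl of compound 1 but changes what hangs on it: (4-methoxyphenyl)amino in place of 4-fluorophenyl on a carbonyl carbon. The carbonyl group therefore becomes a urea rather than an amide.

Within the data shown here, no measured step covers this exact change. Among the measured compounds shown here, the steps that bear on it are those that alter the same nitrogen-bound acyl group in compound 1, and both were modest and weakening: a 3.1-fold higher number from compound 1 to compound 2 (0.49 log units; beyond the scatter) and a 2.5-fold higher number from compound 1 to compound 3 (0.40 log units; beyond the scatter). Since the carbonyl of compound 1 is retained here, the expected step for compound 4 is smaller, in the weakening direction or none beyond the scatter, a 1.5-fold higher number from compound 1 to compound 4 (0.17 log units; within the scatter). Compound 4 is estimated at 1800 nM, with a range from 600 nM to 5500 nM.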

Compound 4, half-maximal inhibitory concentration: 7.9 nM
Beside the measured number, compound 4's estimate is 230-fold (2.36 log units) above it; measured number below the stated range.
By their numbers in this assay, from the lowest: compound 4; then compound 1; then compounds 3 and 2 (each within the scatter of the next).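

In this assay, among these compounds, the group on the carbonyl carbon proves to be a far stronger control on potency than the earlier compounds suggested, with a 150-fold lower number from compound 1 to compound 4 (2.19 log units; beyond the scatter) on replacing 4-fluorophenyl with (4-methoxyphenyl)amino. The earlier changes at this nitrogen-bound acyl group replaced the whole carbonyl unit with a sulfonyl unit and moved the number only modestly and in the weakening direction, with a 3.1-fold higher number from compound 1 to compound 2 (0.49 log units; beyond the scatter) and a 2.5-fold higher number from compound 1 to compound 3 (0.40 log units; beyond the scatter), so they gave no sign that this position could yield a large gain in potency. Nothing available here explains why the amide-to-urea change has such a large effect.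

The entering group differs from the leaving one in two ways at once, bringing an amino nitrogen on the carbonyl carbon and a methoxy group in place of the fluorine, so the compounds shown do not reveal whether one of these accounts for the gain or both are needed. A (4-fluorophenyl)amino group on the same carbonyl carbon would separate the two, while a 4-methoxyphenyl group there, with no amino nitrogen, would test the methoxy group alone.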